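This account rests on a few compounds, and the source may have more. Where it says the series, first, only, none or still open, it means among the compounds named here.

The shared core of this small series is seen in compound 2 `CN(CC1=CC[C@H]2C[C@@H]1C2(C)C)Cc1ccc(-c2cccc([N+](=O)[O-])c2)cc1`. Among the measured compounds shown here, in an assay on HEK293 cells for displacement of a labelled ligand from C-X-C chemokine receptor type 3 (Homo sapiens) (on this read-out higher numbers stand for weaker inhibition and lower numbers for stronger inhibition), compound 2 gives 2000 nM, the only plain number among the values shown. Compound 1 `CN(CC1=CC[C@H]2C[C@@H]1C2(C)C)Cc1ccc(-c2ccccc2F)cc1` carries a 2-fluorophenyl group where compound 2 carries a 3-nitrophenyl group. In this assay compound 1 gives > 316 nM, which is a limit of the assay and not a number. The step that the limit leaves unreadable from compound 1 to compound 2 cannot be read in size, since the limit of > 316 nM in this assay, at which 1 of the 2 values shown sits, leaves one end of it open.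

Compound 3 `CN(CC1=CC[C@H]2C[C@@H]1C2(C)C)Cc1ccc(-c2ccoc2)cc1` has not yet been measured. It differs from compound 2 by furan-3-yl in place of 3-nitrophenyl on an aromatic carbon. For the measured compounds named here, no measured step concerns a change of this kind, and the single step that exists is unreadable, so there is no basis for expecting a shift in either direction beyond the usual scatter. Compound 3 is therefore estimated to give 2000 nM in this assay, with a range from 500 nM to 8000 nM. The step expected no change at the digits printed from compound 2 to compound 3 (within the scatter) is accordingly taken as none beyond the scatter.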

Compound 3, inhibition constant: 6310 nM
Beside the measured number, compound 3's estimate is 3.2-fold (0.50 log units) below it, within the range that was stated.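

This is the only readable step among those shown at this position, an aromatic carbon para to a large group: in this assay, furan-3-yl in place of 3-nitrophenyl gives a 3.2-fold higher number from compound 2 to compound 3 (0.50 log units; beyond the scatter), and a higher number here means weaker inhibition. It shows that the group on this carbon can change the read-out, although the swap alters two things at once: a six-membered aromatic ring of carbon only gives way to a five-membered aromatic ring with a hetero atom, and the nitro group is lost, so this one step cannot separate the two changes. The steps that start from compound 1 cannot be read in size, since its value is a limit of the assay and not a number: the limit of > 316 nM in this assay, at which 1 of the 3 values shown sits.

A plain phenyl group, or a phenyl ring with a nitrile or an amine in the place of the nitro group, would help show whether the ring or the nitro group matters more. Also open, going by these compounds, is how a thiophene or a pyridine ring at this position would compare with furan-3-yl, and why the step has the direction it has.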